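The source may hold more compounds than are shown below. What is called first, only, known or untested is meant among the compounds shown, and "the series" means these compounds.

Measured so far:
compound 1 `O=C(Nc1cccc(-n2cc(-c3ccncc3)c(-c3cc(O)cc(Cl)c3)n2)c1)Nc1ccc(Cl)c(C(F)(F)F)c1`: 3.69%
compound 2 `O=C(Nc1cccc(-n2cc(-c3ccncc3)c(-c3cc(O)cc(Cl)c3)n2)c1)Nc1ccc(Cl)c(Cl)c1`: -14.8%

In a functional assay on OVCAR-8 cells (Homo sapiens) for inhibition, read by sulforhodamine B assay, with a stated time of 48 h, tested at 10 uM (a lower number here means a stronger effect, a higher number a weaker effect of the compound at the concentration tested), compound 2 stands lowest of the two numbers, the nearest being compound 1, which sits higher by the step of a number 18.5 percentage points lower from compound 1 to compound 2 (beyond the scatter). Compound 3 `COc1cc(Cl)cc(-c2nn(-c3cccc(NC(=O)Nc4ccc(Cl)c(Cl)c4)c3)cc2-c2ccncc2)c1` differs from compound 2 in one place: methyl in place of hydrogen on an oxygen on an aromatic ring, that is, hydroxy to methoxy. Among the measured compounds shown here, no measured step touches this oxygen; the only step available, a number 18.5 percentage points lower from compound 1 to compound 2 (beyond the scatter), concerns the chloro for trifluoromethyl exchange elsewhere and says nothing about the methoxy. The expected change from compound 2 to compound 3 is therefore a number 9.8 percentage points higher from compound 2 to compound 3 (within the scatter), with no direction beyond the scatter. Compound 3 is estimated at -5%, within -30% to 20%.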

Compound 3, a percentage reported as activity, at one concentration (the size of the read-out at that concentration, not a potency): 1.93%
Estimate against measurement, compound 3: 6.9 percentage points below; measured number inside the range.
By their numbers in this assay, from the lowest: compound 2; then compounds 3 and 1 (each within the scatter of the next).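

In this assay, this oxygen is the first site shown to respond to capping: hydroxy to methoxy gives a number 16.7 percentage points higher from compound 2 to compound 3 (beyond the scatter) and so weakens the effect at the concentration tested. This step is read only with the chloro in place in compound 2, not with the trifluoromethyl of compound 1. No measurement shown accounts for the step. The compounds shown leave open whether an ethyl on this oxygen, or an amine in place of the hydroxy, would retain the effect of compound 2.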